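Methoxy on compound 3: expected solubility

The source may report more compounds than this note shows. Statements on the series, on what has been measured and on what is new or still open speak of the compounds shown alone.

Measured in a physicochemical assay for solubility, read by spectrophotometry, in phosphate buffer, measured as kinetic solubility, with a stated time of 18 h, at pH 7.4 (a lower number here means a less soluble compound, a higher number a more soluble compound), so far:
- compound 1 `O=C(O)COc1cc(Cl)c(C(=O)Nc2cccc(-c3nc4ccccc4s3)c2)cc1[N+](=O)[O-]` gives 6700 nM
- compound 2 `O=C(Nc1cccc(-c2nc3ccccc3s2)c1)c1cc([N+](=O)[O-])c(O)cc1Cl` gives 2200 nM
- compound 3 `O=C(Nc1cccc(-c2nc3ccccc3s2)c1)c1cc([N+](=O)[O-])ccc1Cl` gives 580 nM

Compound 3 stands lowest of the three at 580 nM on these numbers. Compound 4 `COc1cc(Cl)c(C(=O)Nc2cccc(-c3nc4ccccc4s3)c2)cc1[N+](=O)[O-]` differs from compound 3 by one change. That change is methoxy in place of hydrogen on an aromatic carbon and it puts methoxy in place of hydrogen on an aromatic carbon, ortho to a nitro group, meta to a chloro group and para to a large group. Two measured steps end at hydrogen on that same carbon: a 3.8-fold lower number from compound 2 to compound 3 (0.58 log units; beyond the scatter) is modest and a 12-fold lower number from compound 1 to compound 3 (1.06 log units; beyond the scatter) is large. The step of a 3.0-fold lower number from compound 1 to compound 2 (0.48 log units; beyond the scatter) between the two oxygen-linked groups is also modest. Among the compounds with values here, no compound with methoxy has been measured, so these steps show the scale of change at this carbon but not the outcome for methoxy. Going by these compounds, no step beyond the scatter is expected in this assay here, though a modest move either way remains open. The estimated change is a 1.2-fold lower number from compound 3 to compound 4 (0.06 log units; within the scatter) in this reading. For compound 4 the estimated value is 500 nM with an expected range from 170 nM to 1800 nM at its ends.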

Compound 4, solubility: 10 nM
Compound 4: the middle estimate sits 50-fold (1.70 log units) above what was measured; measured number below the stated range.
By their numbers in this assay, from the lowest: compound 4; then compound 3; then compound 2; then compound 1.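

In this assay, within the data shown here, methoxy is the first group on this carbon, ortho to a nitro group, to give a lower number than hydrogen, with a 58-fold lower number from compound 3 to compound 4 (1.76 log units; beyond the scatter) in place of the higher numbers seen for hydroxy and carboxymethoxy. An oxygen on this carbon therefore does not by itself go with the higher numbers, since a 220-fold lower number from compound 2 to compound 4 (2.34 log units; beyond the scatter) on replacing the hydrogen on that oxygen with methyl and a 670-fold lower number from compound 1 to compound 4 (2.83 log units; beyond the scatter) on the change from carboxymethoxy show that the group on that oxygen decides the outcome in this set. No measurement in hand explains the size of these steps.

Still open, going by these compounds, is whether the low number is particular to methoxy or extends to a longer chain on the same oxygen. Also open, on these data alone, is whether an amine on this carbon would fall with methoxy or with hydroxy.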